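This account rests on a few compounds, and the source may have more. Where it says the series, first, only, none or still open, it means among the compounds named here.

Compound 1 `COc1ccccc1C(=O)NCc1ccc(CNS(=O)(=O)c2ccccc2)cc1` and compound 2 `Cc1ccc(C(=O)NCc2ccc(CNS(=O)(=O)c3ccc(C)cc3)cc2)cc1` share a core and were both tested in an assay on MDA-MB-231 cells for binding affinity to C-X-C chemokine receptor type 4 (Homo sapiens), read by immunofluorescence and microscopy, with stated times of 10 min and 30 min; a lower number here means that less compound is needed, a higher number that more compound is needed for the effect. Going by the values given here, compound 1 gives 1 nM in this assay, the lower of the two numbers known so far, while compound 2 gives 1000 nM. Compound 3 `O=C(NCc1ccc(CNS(=O)(=O)c2ccccc2)cc1)c1ccc(Cl)cc1` has not yet been measured. It differs from compound 1 in one place: 4-chlorophenyl in place of 2-methoxyphenyl on a carbonyl carbon. Among the compounds with values here, no step between two measured compounds that differ in only one place is available to guide this change. The step from compound 1 to compound 3 is expected to be a 20-fold higher number from compound 1 to compound 3 (1.30 log units; beyond the scatter), a rise beyond the usual scatter. Compound 3 is estimated at 20 nM, within 2 nM to 300 nM.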

Compound 3, effective concentration (reported as EC, without a stated level of effect): 100 nM
The estimate for compound 3 lay 5.0-fold (0.70 log units) below the measured number; measured number inside the range.
By their numbers in this assay, from the lowest: compound 1; then compound 3; then compound 2.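

Putting 4-chlorophenyl in place of 2-methoxyphenyl on the carbonyl carbon gives a 100-fold higher number from compound 1 to compound 3 (2.00 log units; beyond the scatter) in this assay. Going by these compounds alone, this is the first single-place comparison, and it shows that the number depends strongly on which substituted phenyl sits at this position, even with the rest of compound 1 unchanged. Nothing measured here explains the size of this step. The substituent and its printed ring position change together, so their contributions remain unseparated. Plain phenyl, 2-chlorophenyl or 4-methoxyphenyl at this position would be needed to tell them apart.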